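Two hydrazones measured, a third awaiting its value

The source may hold more compounds than are shown below. What is called first, only, known or untested is meant among the compounds shown, and "the series" means these compounds.

Compound 1 `CC1=C/C(=N\NC(=O)c2ccncc2)c2c(O)cccc2C1=O`: 2.86
Compound 2 `CC1=C/C(=N\NC(=O)c2cccnc2)c2c(O)cccc2C1=O`: 3.13

Of the compounds shown here, two sharing one core have been measured in a physicochemical assay for lipophilicity; a lower number here means a more polar compound, a higher number a more lipophilic compound. Going by the values given here, compound 1 gives 2.86 and compound 2 gives 3.13; the one step that connects them, a number 0.27 log units higher from compound 1 to compound 2 (within the scatter), is a swap of pyridin-3-yl for pyridin-4-yl on the carbonyl carbon. Compound 2 therefore carries the higher of the two numbers, but the two values sit within the scatter of each other, so no order can be read from them.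

Compound 3 `CC1=C/C(=N\NC(=O)c2ccccc2O)c2c(O)cccc2C1=O` is the next structure, not yet measured in this assay. It differs from compound 2 in one place: 2-hydroxyphenyl in place of pyridin-3-yl on a carbonyl carbon. Among the compounds with values here, the only measured step, from a pyridyl to another pyridyl, does not involve a carbon-only ring or a hydroxyl, so it offers little direct guidance on the size of this change. Within the data shown here, with no closely matching step on record, the expectation for compound 3 rests on the structural change alone, and a rise of about a number 0.87 log units higher from compound 2 to compound 3 (beyond the scatter) is expected. Compound 3 is thus estimated at 4, with a range from 3.4 to 4.6.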

Compound 3, partition coefficient: 4.17
Compound 3: the middle estimate sits 0.17 log units below what was measured; the measured number falls inside the stated range.
By their numbers in this assay, from the lowest: compounds 1 and 2 (each within the scatter of the next); then compound 3.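

In this assay this place on the carbonyl carbon turns out to be able to shift the number well beyond the scatter, which the two pyridyl compounds alone did not show: with 2-hydroxyphenyl in place of pyridin-3-yl the result is a number 1.04 log units higher from compound 2 to compound 3 (beyond the scatter), and with 2-hydroxyphenyl in place of pyridin-4-yl it is a number 1.31 log units higher from compound 1 to compound 3 (beyond the scatter). Both large steps exchange a ring with one hetero atom for a ring of carbon only that carries a hydroxyl, and among these three compounds that exchange counts for far more than the swap between the two pyridyl groups, whose values stay within the scatter of each other. No measurement at hand accounts for the size of these steps.

The carbon-only ring and the hydroxyl enter together here, so the compounds shown cannot divide the rise between them, and whether a plain phenyl or a methoxyphenyl at this place would stand nearer to compound 2 or to compound 3 stays open. Equally open, as far as these compounds go, is how this number would respond to an amine or a carboxylic acid on the ring.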